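Aryl change on the ring nitrogen: compound 4 outlook

The source may report more compounds than this note shows. Statements on the series, on what has been measured and on what is new or still open speak of the compounds shown alone.

Three members of the series have been measured in an assay on isolated protein for inhibition of Polyunsaturated fatty acid 5-lipoxygenase (Homo sapiens), read by HPLC, with a stated time of 15 min, in the presence of a further agent that is not named here; a lower number here means a stronger inhibitor, a higher number a weaker inhibitor. Compound 2 `CC(C)(C)c1ccc(CN2CCN(C(=O)CCc3cc(-c4ccc(F)cc4)n(-c4ccccc4)n3)CC2)cc1` gives 2500 nM, the lowest of the three numbers, though neither neighbour is separated from it beyond the scatter: compound 1 `CC(C)(C)c1ccc(CN2CCN(C(=O)CCc3cc(-c4ccc(F)cc4)n(-c4ccc(Cl)cc4)n3)CC2)cc1` gives 2600 nM and compound 3 `CC(C)(C)c1ccc(CN2CCN(C(=O)CCc3cc(-c4ccc(C(F)(F)F)cc4)n(-c4ccccc4)n3)CC2)cc1` gives 2900 nM. Among the measured compounds shown here, the two single-point steps so far are flat: a 1.0-fold lower number from compound 1 to compound 2 (0.02 log units; within the scatter), and a 1.2-fold higher number from compound 2 to compound 3 (0.06 log units; within the scatter).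

Compound 4 `CC(C)(C)c1ccc(CN2CCN(C(=O)CCc3cc(-c4ccc(F)cc4)n(-c4ccc5ccccc5n4)n3)CC2)cc1` carries quinolin-2-yl in place of phenyl on an aromatic nitrogen. For the measured compounds named here, the only measured step touching this ring is the one from compound 1 to compound 2, the removal of a chloro, which stayed within the scatter; no measured step covers an exchange of the whole ring for a bicyclic one, so the outcome rests on the general flatness seen so far. On that basis no step beyond the scatter is expected in this assay , with wide uncertainty. Compound 4 is therefore estimated at 2500 nM, with a range from 800 nM to 8000 nM. The expected step is no change at the digits printed from compound 2 to compound 4 (within the scatter).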

Compound 4, half-maximal inhibitory concentration: 2800 nM
Compound 4: the middle estimate sits 1.1-fold (0.05 log units) below what was measured; low and high end bracket the measured number.
By their numbers in this assay, from the lowest: compounds 2, 1, 4 and 3 (each within the scatter of the next).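

In this assay this position on the aromatic nitrogen tolerates the exchange of a whole ring for a bicyclic one, not only the loss of a chloro: quinolin-2-yl gives a 1.1-fold higher number from compound 2 to compound 4 (0.05 log units; within the scatter) and a 1.1-fold higher number from compound 1 to compound 4 (0.03 log units; within the scatter) in the same series. The added ring and the hydrogen-bond acceptor of quinolin-2-yl therefore leave the number within the scatter of both phenyl and 4-chlorophenyl, so no group at this position has yet separated from the others. Nothing available accounts for this flatness.

As far as these compounds go, it remains open whether a carboxylic acid or an aminomethyl group on this aryl ring, or a methyl in place of the whole ring, would move the number beyond the scatter. From the compounds shown here alone, it is equally open whether a longer chain leading to the carbonyl in the core of compound 2 would do so.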